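This account rests on a few compounds, and the source may have more. Where it says the series, first, only, none or still open, it means among the compounds named here.

Compound 1 `N/C(=N\NC(=S)N1CCSCC1)c1ccccn1`: 16.3%
Compound 2 `N/C(=N\NC(=S)N1CCN(c2ccccn2)CC1)c1ccc(F)cn1`: 13.4%
Compound 3 `Cc1cccc(/C(N)=N/NC(=S)N2CCCC2)n1`: 17.4%

Of the compounds shown here, three have been measured in a functional assay on MCF7 cells (Homo sapiens) for cytotoxicity, read by MTT assay, with a stated time of 72 h, tested at 1 uM; on this read-out lower numbers stand for less inhibition of growth and higher numbers for more inhibition of growth at the one concentration tested. In this assay compound 1 gives 16.3%, compound 2 gives 13.4% and compound 3 gives 17.4%. The three numbers lie within the usual scatter of one another, so compound 2 cannot be set apart from compound 1 or from compound 3 on this read-out; all three show only modest inhibition of growth at the single concentration tested. No pair of these compounds differs in just one place, so no single step can be read off from them.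

Compound 4 `N/C(=N\NC(=S)N1CCN(c2ccccn2)CC1)c1ccccn1` has not yet been measured. It differs from compound 2 in one place only: hydrogen in place of fluoro on an aromatic carbon. A fluorine atom is removed and nothing but a hydrogen takes its place, with the rest of the molecule unchanged.

Since nothing measured here shows what such a change does, and since compound 2 itself sits among three close numbers, the step is expected to be small, with no direction beyond the scatter: a number 1.6 percentage points higher from compound 2 to compound 4 (within the scatter). Compound 4 is therefore estimated to give about 15% in this assay, somewhere between 7% and 25%.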

Compound 4, percent growth inhibition at one concentration: 36%
Estimate against measurement, compound 4: 21 percentage points below; measured number outside the range, above it.
By their numbers in this assay, from the lowest: compounds 2, 1 and 3 (each within the scatter of the next); then compound 4.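

Replacing the fluoro with hydrogen, the change from 5-fluoropyridin-2-yl to pyridin-2-yl, gives in this assay a number 22.6 percentage points higher from compound 2 to compound 4 (beyond the scatter). Going by these compounds alone, the earlier compounds offered no single-place step, and their numbers all lay within the scatter of one another, so this is the first sign that this aromatic carbon, para to a large group and two atoms from the ring nitrogen, matters for growth inhibition at the one concentration tested. Nothing available explains why removing this one fluorine has such an effect.

The compounds shown compare only hydrogen and fluoro at this carbon, so it remains open whether chloro, methoxy or an amine there would track hydrogen or fluoro. On these data alone, it is also open whether the same swap would have a similar effect with a different ring at the other end of the molecule, as in compound 1.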